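The compounds below may be only part of what the source reports. "The series", "measured", "known", "first", "only" and "open" are said of these compounds alone.

Two compounds of the series have numbers in a functional assay on HEK293 cells for activation of melanin-concentrating hormone receptor 1 (Homo sapiens), read by inositol phosphate accumulation (on this read-out lower numbers stand for an effect already at smaller amounts and higher numbers for an effect only at larger amounts of compound), so far. Compound 1 `CCCc1cc(N)c2cc(NC(=O)/C=C/c3ccc(Br)cc3)ccc2n1` gives 93 nM in this assay. Compound 2 `CCCc1cc(NC)c2cc(NC(=O)/C=C/c3ccc(C(F)(F)F)cc3)ccc2n1` carries methylamino on the core and trifluoromethyl on the cinnamoyl phenyl ring in place of the amino and bromo of compound 1. In this assay compound 2 gives 150 nM. Compound 1 has the lower of the two numbers, but compound 2 lies within the scatter of it, so the two values show no difference that can be read as an order. Going by the values given here, no single-change step between measured compounds is available, and compound 2 differs from compound 1 in two places at once.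

Compound 3 `CCCc1cc(N)c2cc(NC(=O)/C=C/c3ccc(I)cc3)ccc2n1` is still to be measured in this assay. It differs from compound 1 in one place: iodo in place of bromo on an aromatic carbon. The exchange of one halogen for a neighbouring one keeps the count of heavy atoms, donors, acceptors and charge unchanged. The step is expected to stay within the scatter, with no direction claimed beyond it; the estimated step is a 1.2-fold lower number from compound 1 to compound 3 (0.07 log units; within the scatter). Compound 3 is therefore expected to give about 80 nM, with a range from 35 nM to 190 nM.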

Compound 3, half-maximal effective concentration: 280 nM
The estimate for compound 3 lay 3.5-fold (0.54 log units) below the measured number, outside the stated range (above it).
By their numbers in this assay, from the lowest: compounds 1, 2 and 3 (each within the scatter of the next, the first and the last beyond it).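

The exchange of bromo for iodo, read as 4-bromophenyl to 4-iodophenyl, gives the series its first single-change step in this assay: a 3.0-fold higher number from compound 1 to compound 3 (0.48 log units; beyond the scatter). The earlier pair of compounds could show nothing of this kind, as its two members differ in two places at once; this step isolates one aromatic carbon, para to a large group, and shows that the number there responds to the identity of the halogen. The change leaves the counts of heavy atoms, hydrogen-bond donors and hydrogen-bond acceptors untouched and adds no net charge, so a shift beyond the scatter arises here without any difference in those counts, and no measurement at hand bears on what lies behind it.

On these data alone, with only two halogens compared at this carbon, one step gives a direction for this pair and no trend; whether chloro or fluoro would extend it, and where a nitrile or a methoxy group would fall, remains open. Also open, as far as these compounds go, is what methylamino in place of amino on the shared core does alone, and what trifluoromethyl in place of bromo does alone, as compound 2 carries both changes together.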